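Swapping a tert-butyl for an ethoxycarbonyl on the far ring

A few compounds are considered here, and "the series" means these few. Any claim that something is new, unique, unknown or untested is made for them only; others in the source may bear on it.

Measured so far in a functional assay for agonist activity at G protein-coupled receptor 88 (Homo sapiens), read by HTRF and cAMP accumulation; a higher number here means that more compound is needed for the effect, a lower number that less compound is needed:
- compound 1 `CC(C)(N)CN(C(=O)[C@@H]1C[C@H]1c1ccccc1)c1ccc(-c2ccccc2)cc1` gives 1.4 nM
- compound 2 `CC[C@H](C)[C@H](N)CN(C(=O)[C@@H]1C[C@H]1c1ccncc1)c1ccc(-c2ccccc2)cc1` gives 1500 nM
- compound 3 `CC[C@H](C)[C@H](N)CN(C(=O)[C@@H]1C[C@H]1c1ccccc1)c1ccc(-c2ccc(C(C)(C)C)cc2)cc1` gives 750 nM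

Compound 3 holds the second highest of the three numbers in this assay. Its nearest neighbour is compound 2, whose number is close enough to lie within the usual scatter of repeated measurements, so the two cannot be told apart. Its furthest neighbour is compound 1, whose much lower number lies well beyond that scatter.

Compound 4 `CCOC(=O)c1ccc(-c2ccc(N(C[C@@H](N)[C@@H](C)CC)C(=O)[C@@H]3C[C@H]3c3ccccc3)cc2)cc1` is not yet measured. It differs from compound 3 in a single place: ethoxycarbonyl in place of tert-butyl on an aromatic carbon. No pair of measured compounds differs in just this way, so the shown numbers give no direct guide to the size or direction of this step. With nothing to lean on, the expectation is for a step from compound 3 that stays within or only modestly outside the scatter, a 1.3-fold lower number from compound 3 to compound 4 (0.10 log units; within the scatter). For compound 4 the estimate in this assay is 600 nM, with a range from 100 nM to 4000 nM.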

Compound 4, half-maximal effective concentration: 260 nM
Beside the measured number, compound 4's estimate is 2.3-fold (0.36 log units) above it; low and high end bracket the measured number.
By their numbers in this assay, from the lowest: compound 1; then compound 4; then compounds 3 and 2 (each within the scatter of the next).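

In this assay, the change gives a 2.9-fold lower number from compound 3 to compound 4 (0.46 log units; beyond the scatter), the first step among these compounds that isolates a single place. It shows that the number responds to what sits on this aromatic carbon, para to a large group, and that a group with 2 hydrogen-bond acceptors and a carbonyl is accepted there in place of one with no acceptors. The step is modest but beyond the scatter, and nothing measured here explains it.

On these data alone, it remains open whether the whole ethoxycarbonyl matters or only part of it; a carboxylic acid, a methyl ester or a primary amide on the same carbon would help separate these. Also open, as far as these compounds go, is whether ethoxycarbonyl would have a similar effect on the core of compound 1.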